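Series notes: bis-benzylidene cyclohexanones in the SW-620 read-out

The source may report more compounds than this note shows. Statements on the series, on what has been measured and on what is new or still open speak of the compounds shown alone.

Measured so far:
Compound 1 `COc1cccc(/C=C2\CCC/C(=C\c3ccc(O)c(Cl)c3)C2=O)c1OC`: 16800 nM
Compound 2 `COc1ccc(/C=C2\CCC/C(=C\c3ccc(Cl)cc3)C2=O)cc1OC`: 5900 nM
Compound 3 `COc1ccc(/C=C2\CCC/C(=C\c3cc(OC)c(OC)c(OC)c3)C2=O)cc1OC`: 1800 nM

In a functional assay on SW-620 cells (Homo sapiens) for cytotoxicity, read by MTT assay, with a stated time of 72 h (on this read-out lower numbers stand for stronger inhibition and higher numbers for weaker inhibition), compound 2 gives 5900 nM, the second highest of the three numbers. Its nearest neighbour is compound 1, whose value of 16800 nM is higher by a gap beyond the usual scatter; the furthest is compound 3, whose 1800 nM is lower, again beyond the scatter.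

Compound 4 `COc1ccc(/C=C2\CCC/C(=C\c3ccc(O)c(Cl)c3)C2=O)cc1OC` has not yet been run in this assay. It is derived from compound 2 by one change: 3-chloro-4-hydroxyphenyl in place of 4-chlorophenyl on a double-bonded chain carbon bound to a double-bonded ring carbon.

Within the data shown here, no step between measured compounds that differ in one place is available, so the size of this step has to be judged from the whole set. Compound 1 also carries the entering group, yet it differs from compound 4 in another part of the molecule. For that reason the value of compound 1, 16800 nM, is only a loose guide. Compound 4 is therefore expected to land close to compound 2, with a step of a 1.4-fold higher number from compound 2 to compound 4 (0.13 log units; within the scatter) that may well fall within the scatter or lean toward a somewhat higher number. The estimate for compound 4 in this assay is 8000 nM, with a range from 3000 nM to 22000 nM.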

Compound 4, half-maximal inhibitory concentration: 7100 nM
Compound 4: middle estimate off by 1.1-fold (0.05 log units), on the high side; measured number inside the range.
By their numbers in this assay, from the lowest: compound 3; then compounds 2 and 4 (each within the scatter of the next); then compound 1.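

Among these compounds, the exchange gives a 1.2-fold higher number from compound 2 to compound 4 (0.08 log units; within the scatter) in this assay, and this is the first step that can be read at a single place. On a double-bonded chain carbon bound to a double-bonded ring carbon, this read-out does not separate 3-chloro-4-hydroxyphenyl from 4-chlorophenyl, although the entering group carries a hydrogen-bond donor and a hydrogen-bond acceptor that the leaving group lacks, so adding them at this place, together with the change in the chlorine's place on the ring, leaves the number within the scatter. No available data offer an explanation for this flat step.

Among the compounds shown here, the flat step covers only this one exchange on this one core, and the separate contributions of the hydroxyl and the chlorine cannot be drawn from it. As far as these compounds go, whether a 4-aminophenyl or a 4-carboxyphenyl group at this place would also leave the number unmoved stays open, as does which feature of the group on compound 3 goes with its lower number of 1800 nM in this assay.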